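Flipping One Ring Stereocentre: From Compound 2 to Compound 3

The compounds below may be only part of what the source reports. "The series", "measured", "known", "first", "only" and "open" are said of these compounds alone.

Compound 1: `CCCCCCCCCCCSc1ccccc1C(SCCC(=O)O)SCCC(=O)O`, 646 nM
Compound 2: `CCCCCCCCCCCCc1ccccc1C1S[C@H](C(=O)O)[C@H](C(=O)O)S1`, 17600 nM

In an assay on membranes from lung (Cavia porcellus) for binding affinity to cysteinyl leukotriene receptor (Homo sapiens) (a lower number here means a stronger inhibitor, a higher number a weaker inhibitor), compound 1 gives 646 nM and compound 2 gives 17600 nM, the higher of the two numbers and a gap beyond the scatter. Compound 3 `CCCCCCCCCCCCc1ccccc1C1S[C@@H](C(=O)O)[C@H](C(=O)O)S1` keeps every atom and bond of compound 2 and differs in configuration alone: the two compounds have the same atoms and bonds; at least one stereo element is drawn with a configuration in one of them and without one in the other: 1 of 3 stereo elements differ; a stereocentre at a saturated ring carbon is drawn R in compound 2 and S in compound 3. Among the compounds with values here, no measured pair here shows what such an inversion at the ring does, so the step is expected to be modest, in either direction, and possibly none beyond the scatter. Compound 3 is estimated at 10000 nM, within 2500 nM to 40000 nM. This corresponds to an expected step of a 1.8-fold lower number from compound 2 to compound 3 (0.25 log units; within the scatter).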

Compound 3, inhibition constant: 401 nM
Compound 3: the middle estimate sits 25-fold (1.40 log units) above what was measured; measured number outside the range, below it.
By their numbers in this assay, from the lowest: compounds 3 and 1 (each within the scatter of the next); then compound 2.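

In this assay, the configuration at this saturated ring carbon counts for a great deal: going from R to S gives a 44-fold lower number from compound 2 to compound 3 (1.64 log units; beyond the scatter) with atoms and bonds unchanged. Within the data shown here, the earlier compounds held no pair that isolated this stereocentre, so this is the first sign that the number depends on configuration at this position. The reading carries one caution about the drawings: the fact that one of compounds 2 and 3 is drawn with a defined configuration and the other without, at the place where they differ.

The compounds shown leave open whether the other ring stereocentres matter as much, and whether a tetrazole in place of a carboxylic acid on the ring would keep the number of compound 3.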